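Ring swap on the shared core: compound 3 to compound 4

The source may report more compounds than this note shows. Statements on the series, on what has been measured and on what is new or still open speak of the compounds shown alone.

For the measured compounds named here, the three measured members keep one core and differ only in the substituent on a nitrogen on an aromatic ring. Compound 1 `N#Cc1cnc(NCc2cnccc2C(F)(F)F)cc1N[C@H]1CC[C@H](O)CC1` gives 350 nM in an assay on isolated protein for inhibition of protein kinase C theta type (Homo sapiens), read by TR-FRET, with a stated time of 2 h; a lower number here means a stronger inhibitor, a higher number a weaker inhibitor. Compound 2 `CO[C@H]1CC[C@H](CNc2cc(NCc3cnccc3C(F)(F)F)ncc2C#N)CC1` gives 330 nM in this assay, and the step of a 1.1-fold lower number from compound 1 to compound 2 (0.03 log units; within the scatter) lies within the scatter. Compound 3 `CC1(C)C[C@H](Nc2cc(NCc3cnccc3C(F)(F)F)ncc2C#N)CC[C@H]1O` gives 100 nM in this assay; the steps of a 3.5-fold lower number from compound 1 to compound 3 (0.54 log units; beyond the scatter) and a 3.3-fold lower number from compound 2 to compound 3 (0.52 log units; beyond the scatter) both lie beyond the scatter, so compound 3 stands at the lowest number of the three.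

Compound 4 `CC1(C)[C@H](Nc2cc(NCc3cnccc3C(F)(F)F)ncc2C#N)C[C@H]1C(N)=O` is not yet measured. The change is 3-carbamoyl-2,2-dimethylcyclobutyl in place of 4-hydroxy-3,3-dimethylcyclohexyl on a nitrogen on an aromatic ring. Going by the values given here, no measured step covers an exchange of this kind: the two steps ending at compound 3 only show that the dimethyl pattern on the hydroxycyclohexyl brought a modest gain, a 3.5-fold lower number from compound 1 to compound 3 (0.54 log units; beyond the scatter), and the step of a 1.1-fold lower number from compound 1 to compound 2 (0.03 log units; within the scatter) shows that reworking the hydroxyl end of that ring changed nothing beyond the scatter. Compound 4 keeps the dimethyl pattern but gives up the six-membered ring and the hydroxyl, so a modest loss is expected rather than a gain. For compound 4 the estimated value in this assay is 250 nM, within a range of 80 nM to 800 nM. This estimate corresponds to an expected step of a 2.5-fold higher number from compound 3 to compound 4 (0.40 log units; beyond the scatter).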

Compound 4, half-maximal inhibitory concentration: 140 nM
Beside the measured number, compound 4's estimate is 1.8-fold (0.25 log units) above it; measured number inside the range.
By their numbers in this assay, from the lowest: compounds 3 and 4 (each within the scatter of the next); then compounds 2 and 1 (each within the scatter of the next).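

In this assay, replacing 4-hydroxy-3,3-dimethylcyclohexyl with 3-carbamoyl-2,2-dimethylcyclobutyl on a nitrogen on an aromatic ring leaves the number within the scatter (a 1.4-fold higher number from compound 3 to compound 4 (0.15 log units; within the scatter)), so at this position neither the six-membered ring nor the hydroxyl is needed to hold the level of compound 3. The advantage over the two other substituents also survives the exchange (a 2.5-fold lower number from compound 1 to compound 4 (0.40 log units; beyond the scatter)) and (a 2.4-fold lower number from compound 2 to compound 4 (0.37 log units; beyond the scatter)), with both steps beyond the scatter, which shows that this level is not confined to a cyclohexyl group carrying a hydroxyl. No measurement on hand explains why these two different substituents give numbers within the scatter of each other.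

As far as these compounds go, compound 4 changes the ring and its polar end group together, so what each change contributes on its own remains open. Also open, from the compounds shown here alone, is whether the cyclobutyl would keep this level without its dimethyl pattern, or with a carboxylic acid or an amine in place of the carbamoyl group.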